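A few compounds are considered here, and "the series" means these few. Any claim that something is new, unique, unknown or untested is made for them only; others in the source may bear on it.

Compound 3, whose structure is `CCCCCCCCCCn1c(=O)n(C2OC(CO)[C@@H](O)[C@H]2O)c2nc(N)nc(O)c21`, was examined in a functional assay on the whole organism with Mus musculus as the target (a higher number here means a larger maximal response, a lower number a smaller maximal response), where it gives 0%. Among the three measured compounds this puts it at the bottom together with compound 2, structure `C=CCn1c(=O)n([C@@H]2O[C@H](CO)[C@H]3OC(C)(CCC(=O)NC)O[C@H]32)c2nc(N)nc(O)c21`, which in this assay gives 0%; the two values agree at the digits shown and lie within the scatter of each other. The furthest point from compound 3 is compound 1, structure `CCCn1c(=O)n(C2OC(COP(=O)(O)O)[C@@H](O)[C@H]2O)c2nc(N)nc(O)c21`, which in this assay gives 57%, a gap that is beyond the scatter.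

The next compound, compound 4, has the structure `Nc1nc(O)c2c(n1)n(C1OC(CO)[C@@H](O)[C@H]1O)c(=O)n2Cc1ccc([N+](=O)[O-])cc1`. It differs from compound 3 in one place: 4-nitrophenyl in place of nonyl on a saturated chain carbon bound to an aromatic nitrogen. For the measured compounds named here, no step between two measured compounds carries this particular exchange, so there is no measured guide for its size. Compound 1, carrying a shorter chain at the same position, shows that a large response is possible on this core, while compound 3 with its longer chain gives none.

From compound 3 to compound 4 a step of a number 25 percentage points higher from compound 3 to compound 4 (beyond the scatter) is expected, upward, of a size beyond the scatter. Compound 4 is therefore estimated to give a maximal response of 25% in this assay, within a range from 0% to 60%.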

Compound 4, largest response reached (reported as maximal response), in percent of the reference or control that the assay uses: 16%
Compound 4: the middle estimate sits 9 percentage points above what was measured, within the range that was stated.
By their numbers in this assay, from the lowest: compounds 2 and 3 (each within the scatter of the next); then compound 4; then compound 1.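

In this assay the exchange of nonyl for 4-nitrophenyl on a saturated chain carbon bound to an aromatic nitrogen gives a number 16 percentage points higher from compound 3 to compound 4 (beyond the scatter) and is the first change shown at a single place, as no earlier pair of compounds differed in one place only. It shows that the maximal response depends on this position with the rest of the structure held constant, and that a response can be measured with the 4-nitrobenzyl group here, where the decyl chain of compound 3 gives 0% in this assay. No measured information about these groups bears on the result, so the step stands without an explanation.

The compounds shown leave open whether the step belongs to the aromatic ring or to the nitro group, and where an unsubstituted benzyl group or a benzyl group carrying an amine would stand. They also leave open how the response on the core of compound 3 would follow the length of the chain at this position, for instance with a pentyl chain.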